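A few compounds are considered here, and "the series" means these few. Any claim that something is new, unique, unknown or untested is made for them only; others in the source may bear on it.

Working notes on the series. Compound 1 `Cn1ncnc1-c1cc(Oc2ccc(NC(=O)N/N=C/c3ccccc3)cc2F)ccn1`, compound 2 `COc1cc(/C=N/NC(=O)Nc2ccc(Oc3ccnc(-c4nncn4CCN(C)C)c3)c(F)c2)cc(OC)c1OC` and compound 3 `CN(C)CCn1cnnc1-c1cc(Oc2ccc(NC(=O)N/N=C/c3c(O)ccc4ccccc34)cc2F)ccn1` share a core and differ in the group on a carbon with a double bond to nitrogen, and elsewhere. In a functional assay on A549 cells (Homo sapiens) for cytotoxicity, read by MTT assay, with a stated time of 72 h (a higher number here means a weaker inhibitor, a lower number a stronger inhibitor), compound 2 reaches only a limit of the assay, reported as > 100000 nM. In this assay compound 1 likewise reports a limit, > 100000 nM. In this assay compound 3 gives a measured number, 880 nM. Compound 2 therefore stands at the limit of > 100000 nM in this assay, at which 2 of the 3 values shown sit, with no number of its own.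

The unmeasured compound 4 `CN(C)CCn1cnnc1-c1cc(Oc2ccc(NC(=O)N/N=C/c3cccc(O)c3)cc2F)ccn1` differs from compound 2 by 3-hydroxyphenyl in place of 3,4,5-trimethoxyphenyl on a carbon with a double bond to nitrogen. Going by the values given here, the one measured step that bears on this is an at least 110-fold lower number from compound 2 to compound 3 (2.05 log units; beyond the scatter), where the entering group was 2-hydroxynaphthalen-1-yl. Compound 4 carries the smaller 3-hydroxyphenyl, and compound 1, which has neither hydroxy nor methoxy on that carbon, also sits at the limit. A move toward the number of compound 3 is expected, but smaller than the measured step, and a reading that stays at the limit remains a real possibility. Compound 4 is expected at 30000 nM, with a range from 3000 nM to 200000 nM. The expected step is an at least 3.3-fold lower number from compound 2 to compound 4 (0.52 log units; beyond the scatter).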

Compound 4, half-maximal inhibitory concentration: > 100000 nM
Compound 4: no number, only a limit; the forecaster's own chance of this, stated with the estimate: 45%; at least 3.3-fold (0.52 log units) between middle value and limit.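

In this assay, putting 3-hydroxyphenyl in place of 2-hydroxynaphthalen-1-yl on the carbon with a double bond to nitrogen gives an at least 110-fold higher number from compound 3 to compound 4 (2.05 log units; beyond the scatter). The earlier compounds shown here left open whether a hydroxy group on this group might suffice, but in compound 4 a hydroxy group on a single phenyl ring does not bring a measured number, so the hydroxy group alone does not reproduce the result of compound 3. The step from compound 2 to compound 4 cannot be read, as both values are limits, so 3-hydroxyphenyl and 3,4,5-trimethoxyphenyl cannot be ranked, and compound 3 remains the only compound with a measured number: the limit of > 100000 nM in this assay, at which 3 of the 4 values shown sit.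

The compounds shown do not separate the contribution of the fused second ring from that of the hydroxy group, and naphthalen-1-yl without the hydroxy group, or 2-hydroxyphenyl, would address this on the same core. As far as these compounds go, it also remains open whether any single-ring group on this carbon, such as a phenyl ring carrying an amine or a carboxylic acid, can reach a measured number.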